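The source may report more compounds than this note shows. Statements on the series, on what has been measured and on what is new or still open speak of the compounds shown alone.

Measured so far in an assay on liver for inhibition of sterol O-acyltransferase 1 (Rattus norvegicus), using microsomes; a lower number here means a stronger inhibitor, a higher number a weaker inhibitor:
compound 1, `C=CCN(CC)S(=O)(=O)NC(=O)Nc1c(C(C)C)cccc1C(C)C`, 2100 nM
compound 2, `CC(C)c1cccc(C(C)C)c1OC(=O)NS(=O)(=O)N1CCCC1`, 53000 nM
compound 3, `CCCCCCNS(=O)(=O)NC(=O)Oc1c(C(C)(C)C)cc(C)cc1C(C)(C)C`, 19400 nM

Compound 2 gives the highest number of the three in this assay; compound 3 lies nearest to it and compound 1 furthest, both gaps beyond the scatter. Compound 1 and compound 3 each differ from compound 2 in more than one place, so none of these gaps can be tied to a single change.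

Compound 4, `CC(C)c1cccc(C(C)C)c1OC(=O)NS(=O)(=O)Oc1ccc(F)cc1F`, is not yet measured. It differs from compound 2 by 2,4-difluorophenoxy in place of pyrrolidin-1-yl on a sulfonyl sulfur. Going by the values given here, no measured pair shows this change on its own, so the step in this assay can only be guessed. The three measured compounds spread widely, with compound 2 at the top, which leaves room on the low side; a move toward a lower number is taken as plausible, but a step within the scatter cannot be excluded.

Compound 4 is estimated at 20000 nM in this assay, with a range from 5000 nM to 80000 nM. The step expected from compound 2 to compound 4 is a 2.7-fold lower number from compound 2 to compound 4 (0.42 log units; beyond the scatter), a moderate move to a lower number.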

Compound 4, half-maximal inhibitory concentration: > 50000 nM
Compound 4: no number, only a limit; the forecaster's own chance of this, stated with the estimate: 10%; at least 2.5-fold (0.39 log units) between middle value and limit.
By their numbers in this assay, from the lowest: compound 1; then compound 3; then compound 2.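

In this assay, compound 4 gives > 50000 nM, which is a limit and not a number. The step from compound 2 to compound 4 therefore cannot be read: the limit of > 50000 nM in this assay, at which 1 of the 4 values shown sits.

The compounds shown leave open how far, and in which direction, 2,4-difluorophenoxy in place of pyrrolidin-1-yl on a sulfonyl sulfur shifts the number in this assay.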